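This account rests on a few compounds, and the source may have more. Where it says the series, first, only, none or still open, it means among the compounds named here.

In a functional assay on MGC-803 cells (Homo sapiens) for antiproliferative activity, read by MTT assay, with a stated time of 72 h (on this read-out lower numbers stand for stronger inhibition and higher numbers for weaker inhibition), compound 3 `CCCSc1nc(N/N=C/c2ccc([N+](=O)[O-])cc2)c2nnn(Cc3ccccc3)c2n1` gives 10100 nM, the lowest of the two numbers shown. Compound 2 `CCCSc1nc(N/N=C/c2ccc(Br)cc2)c2nnn(Cc3ccccc3)c2n1` gives 34900 nM. Compound 1 `CCCSc1nc(N/N=C/c2ccc(C)cc2)c2nnn(Cc3ccccc3)c2n1` gives > 64000 nM, which is a limit of the assay and not a number (the limit of > 64000 nM in this assay, at which 1 of the 3 values shown sits). The measured steps all concern a single group on the aromatic ring: an at least 1.8-fold lower number from compound 1 to compound 2 (0.26 log units; that floor lies within the scatter), an at least 6.3-fold lower number from compound 1 to compound 3 (0.80 log units; beyond the scatter) and a 3.5-fold lower number from compound 2 to compound 3 (0.54 log units; beyond the scatter). Compound 4 `CCCSc1nc(N/N=C/c2ccc3ccccc3c2)c2nnn(Cc3ccccc3)c2n1` differs from compound 3 by naphthalen-2-yl in place of 4-nitrophenyl on a carbon with a double bond to nitrogen. Within the data shown here, no measured step exchanges the whole ring, so none bears directly on this change. Still, the number for compound 4 is expected to rise because a 3.5-fold lower number from compound 2 to compound 3 (0.54 log units; beyond the scatter) and an at least 6.3-fold lower number from compound 1 to compound 3 (0.80 log units; beyond the scatter) show the nitro variant giving the lowest number, and compound 4 has no nitro group; the expected step is a 2.5-fold higher number from compound 3 to compound 4 (0.39 log units; beyond the scatter), placing compound 4 nearer compound 2. Compound 4 is therefore estimated at 25000 nM, with a range from 8000 nM to 80000 nM, and with some chance that only a limit is reported.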

Compound 4, half-maximal inhibitory concentration: > 64000 nM
Compound 4: a limit, no number; the forecaster's own chance of this, stated with the estimate: 20%; middle value at least 2.5-fold (0.40 log units) from the limit.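

In this assay compound 4 gives > 64000 nM, which is a limit and not a number, and the second such value among these compounds: the limit of > 64000 nM in this assay, at which 2 of the 4 values shown sit.

Exchanging the whole group on a carbon with a double bond to nitrogen gives an at least 6.3-fold higher number from compound 3 to compound 4 (0.80 log units; beyond the scatter), so the 2 six-membered aromatic rings of naphthalen-2-yl do not match 4-nitrophenyl here. Among these compounds, the exchange for 4-bromophenyl gives an at least 1.8-fold higher number from compound 2 to compound 4 (0.26 log units; that floor lies within the scatter), which fixes no order between that pair, and the remaining step cannot be read, as both of its values are limits.

The compounds shown leave open how an amine or a nitrile in place of the nitro group would read on the phenyl ring. They also leave open whether a nitro group on naphthalen-2-yl would bring the number down again.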